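Removing a methoxy group from a weak growth inhibitor

This account rests on a few compounds, and the source may have more. Where it says the series, first, only, none or still open, it means among the compounds named here.

Compound 1 `COc1ccc2[nH]cc(C(=O)/C(C#N)=C/C=C(\Cl)c3ccc(OC)c(OC)c3)c2c1` was tested in a functional assay on MCF7 cells (Homo sapiens) for cytotoxicity, read by sulforhodamine B assay, with a stated time of 48 h (a higher number here means a weaker inhibitor of growth, a lower number a stronger inhibitor of growth), where compound 1 gives 44900 nM. Two relatives were measured alongside it. Compound 3 `COc1ccc(/C(Cl)=C/C=C(\C#N)C(=O)c2c[nH]c3ccccc23)cc1OC` gives 44200 nM in this assay, and compound 2 `COc1cc(/C(Cl)=C/C=C(\C#N)C(=O)c2c[nH]c3ccc(Br)cc23)cc(OC)c1OC` gives 30800 nM. All three numbers lie within the scatter of one another, so none of them can be called more or less potent than the others; they describe weak growth inhibitors of about the same strength.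

Compound 4 `COc1ccc(/C(Cl)=C/C=C(\C#N)C(=O)c2c[nH]c3ccc(OC)cc23)cc1` differs from compound 1 in one place: hydrogen in place of methoxy on an aromatic carbon. One measured step speaks to this kind of change. Going from compound 1 to compound 3 also replaces a methoxy group on an aromatic carbon with hydrogen, though not at the same place, and that step reads a 1.0-fold lower number from compound 1 to compound 3 (0.01 log units; within the scatter), a change within the scatter. Nothing else among the three compounds bears on the change, and the measured step gives no reason to expect movement in this assay beyond the scatter in either direction.

The expectation for compound 4 in this assay is therefore a number close to that of compound 1, a step of a 1.0-fold higher number from compound 1 to compound 4 (0.00 log units; within the scatter). Compound 4 is estimated at 45000 nM, with a likely range from 20000 nM to 100000 nM.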

Compound 4, concentration for 50% growth inhibition: 87100 nM
Estimate against measurement, compound 4: 1.9-fold (0.29 log units) below, within the range that was stated.
By their numbers in this assay, from the lowest: compounds 2, 3, 1 and 4 (each within the scatter of the next, the first and the last beyond it).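

In this assay, taking one methoxy group off the aromatic ring, which turns 3,4-dimethoxyphenyl into 4-methoxyphenyl, gives a 1.9-fold higher number from compound 1 to compound 4 (0.29 log units; within the scatter), so this position now has a direct reading of its own, and the loss stays within the scatter, though near its edge. Together with a 1.0-fold lower number from compound 1 to compound 3 (0.01 log units; within the scatter), where a methoxy group leaves at a different place, this shows that two separate single removals of methoxy from compound 1 both leave the number within the scatter, so neither group is shown to be needed for the weak growth inhibition seen here. Nothing given here explains this reading or ties it to any property of the methoxy group.

The compounds shown leave open whether a different group at this place, such as an amine, a carboxylic acid or a longer alkoxy chain, would move the number beyond the scatter in either direction. On these data alone, it also remains open what would happen if both of these methoxy groups left the core of compound 1 together, since each step here removes only one.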